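Removing tert-butoxycarbonyl on two cores in a cytotoxicity series

A few compounds are considered here, and "the series" means these few. Any claim that something is new, unique, unknown or untested is made for them only; others in the source may bear on it.

Compound 1 `COc1ccc(C#Cc2cc(OC)c(OC)c(OC)c2)cc1N` and compound 2 `COc1ccc(C#Cc2cc(OC)c(OC)c(OC)c2)cc1NC(=O)OC(C)(C)C` share one core; compound 3 `COc1ccc(C2CC2c2cc(OC)c(OC)c(OC)c2)cc1NC(=O)OC(C)(C)C` and compound 4 `COc1ccc(C2CC2c2cc(OC)c(OC)c(OC)c2)cc1N` share another, and the difference between the two cores is not broken down here. In a functional assay on HeLa cells (Homo sapiens) for cytotoxicity, read by MTT assay (a lower number here means a stronger inhibitor, a higher number a weaker inhibitor), compound 1 gives only a limit of > 30000 nM rather than a number. In this assay compound 2 also gives only a limit, > 30000 nM. The change from compound 2 to compound 1 is hydrogen in place of tert-butoxycarbonyl on a nitrogen on an aromatic ring, and the step that the two limits leave unreadable from compound 2 to compound 1 cannot be read because of the limit of > 30000 nM in this assay, at which 2 of the 3 values shown sit. In this assay, for the measured compounds named here, compound 3 gives 10100 nM, the single number in the set so far. Going by the values given here, the change from compound 3 to compound 4 is hydrogen in place of tert-butoxycarbonyl on a nitrogen on an aromatic ring, the same change as the one between compound 2 and compound 1, at the same kind of place. The measured pair gives no readable size for this change, so the expectation for compound 4 rests mainly on compound 3 and is held wide. The step from compound 3 to compound 4 is expected to be a 2.0-fold lower number from compound 3 to compound 4 (0.31 log units; beyond the scatter). Compound 4 is estimated at 5000 nM, in a range from 500 nM to 30000 nM.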

Compound 4, half-maximal inhibitory concentration: 41 nM
Beside the measured number, compound 4's estimate is 120-fold (2.09 log units) above it; measured number outside the range, below it.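

On the core shared by compound 3 and compound 4, hydrogen in place of tert-butoxycarbonyl on a nitrogen on an aromatic ring gives, in this assay, a 250-fold lower number from compound 3 to compound 4 (2.39 log units; beyond the scatter). The same change on the core of compound 1 cannot be read, so the series holds one sized instance of this change and no measure of how it carries from one core to the other: the limit of > 30000 nM in this assay, at which 2 of the 4 values shown sit. In this assay compound 1 gives > 30000 nM, which is a limit and not a number, so the result on that core neither matches nor contradicts the large step seen with compound 4.

The compounds shown leave open whether an acetyl or a methyl group on that nitrogen would keep the number of compound 4, or whether the free amino group alone carries it. How far the two cores themselves account for the contrast between compound 1 and compound 4 also stays open.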